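Trading a Pyrrole Arm for a Pyrrolidine Arm

The source may report more compounds than this note shows. Statements on the series, on what has been measured and on what is new or still open speak of the compounds shown alone.

Among the measured compounds shown here, in a functional assay on U-87MG ATCC cells (Homo sapiens) for antiproliferative activity, with a stated time of 3 days (on this read-out higher numbers stand for an effect only at larger amounts of compound and lower numbers for an effect already at smaller amounts), compound 2 (`Cn1cccc1CN(Cc1ccc(O)c2ncccc12)Cc1ccc(O)c2ncccc12`) gives 2 uM and this is the only number available so far. In this assay compound 1 (`Oc1ccc(CN(Cc2ccc(OC(F)(F)F)cc2)Cc2ccc(O)c3ncccc23)c2cccnc12`) has the entry "not determined" (no result reported) and so offers no comparison.

Compound 3 (`Oc1ccc(CN(CCN2CCCC2)Cc2ccc(O)c3ncccc23)c2cccnc12`) keeps the shared core of compound 2 and differs in one place ((pyrrolidin-1-yl)methyl in place of 1-methyl-1H-pyrrol-2-yl on a saturated chain carbon bound to an amine nitrogen), where (pyrrolidin-1-yl)methyl stands in place of 1-methyl-1H-pyrrol-2-yl on a saturated chain carbon bound to an amine nitrogen. For the measured compounds named here, no measured step shows what a swap like this does, so compound 2 at 2 uM is the sole anchor for any expectation. The expected step of a 1.3-fold lower number from compound 2 to compound 3 (0.12 log units; within the scatter) stays within the usual scatter, with no firm direction foreseen. In this assay the value estimated for compound 3 is 1.5 uM with a plausible range from 0.5 uM to 5 uM around it.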

Compound 3, concentration for half-maximal effect: 0.2 uM
Beside the measured number, compound 3's estimate is 7.5-fold (0.88 log units) above it, outside the stated range (below it).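

In this assay, among the compounds shown here, the swap gives a 10-fold lower number from compound 2 to compound 3 (1.00 log units; beyond the scatter), the first sign that the group on this saturated chain carbon bound to an amine nitrogen can shift the read-out beyond ordinary scatter. The leaving and entering groups have the same counts of heavy atoms, hydrogen-bond donors and acceptors, and neither has a net charge, so these counts do not separate them; the visible change is from an aromatic five-membered ring to a non-aromatic one, along with a different attachment. No measurement shown explains the difference.

This single step changes the ring and its attachment together, so it cannot show which change matters. On these data alone, whether a 2-(dimethylamino)ethyl arm, with an open-chain amine instead of the ring, would give a similar number also remains open.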